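Amide variation on the carbonyl carbon of the series

The compounds below may be only part of what the source reports. "The series", "measured", "known", "first", "only" and "open" are said of these compounds alone.

For the measured compounds named here, compound 3 `CC(C)=CCC/C(C)=C/CC/C(C)=C/CSC[C@H](NC(=O)CCCCCN1CCCC1)C(=O)NC1CCCC1` gives 6800 nM in a functional assay on BXPC-3 cells (Homo sapiens) for cytotoxicity, read by fluorescence, with a stated time of 48 h (on this read-out lower numbers stand for an effect already at smaller amounts and higher numbers for an effect only at larger amounts of compound), and stands second highest of the three numbers so far. Compound 2 `CC(C)=CCC/C(C)=C/CC/C(C)=C/CSC[C@H](NC(=O)CCCCCN1CCCC1)C(=O)N1CCCCC1` gives 8700 nM; the step of a 1.3-fold lower number from compound 2 to compound 3 (0.11 log units; within the scatter) lies within the scatter. Going by the values given here, compound 1 `CC(C)=CCC/C(C)=C/CC/C(C)=C/CSC[C@H](NC(=O)CCCCCN1CCN(C)CC1)C(=O)N1CCCC1` gives 3200 nM, a lower number than compound 3 beyond the scatter, but it differs from compound 3 in more than one place, so no single step is computed for that pair. Compound 4 `CC(C)=CCC/C(C)=C/CC/C(C)=C/CSC[C@H](NC(=O)CCCCCN1CCCC1)C(=O)N1CCCC1` carries pyrrolidin-1-yl in place of cyclopentylamino on a carbonyl carbon. Among the compounds with values here, the only measured step that bears on an amide change at this carbonyl carbon is the one already given, and it was within the scatter. On that basis the expected step to compound 4 is a 1.1-fold lower number from compound 3 to compound 4 (0.05 log units; within the scatter), none beyond the scatter. Compound 4 is estimated at 6000 nM, from 2500 nM to 15000 nM.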

Compound 4, half-maximal effective concentration: 6500 nM
Compound 4: middle estimate off by 1.1-fold (0.03 log units), on the low side, and the stated range covers the measured number.
By their numbers in this assay, from the lowest: compound 1; then compounds 4, 3 and 2 (each within the scatter of the next).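

On the carbonyl carbon, the change from cyclopentylamino to pyrrolidin-1-yl removes the amide hydrogen, yet this assay shows no readable change (a 1.0-fold lower number from compound 3 to compound 4 (0.02 log units; within the scatter)), and the change from piperidin-1-yl to pyrrolidin-1-yl also stays within the scatter (a 1.3-fold lower number from compound 2 to compound 4 (0.13 log units; within the scatter)). Compound 4 also isolates the amine on the saturated chain carbon, five bonds along the chain from a carbonyl carbon: pyrrolidin-1-yl in place of 4-methylpiperazin-1-yl gives a modest step beyond the scatter (a 2.0-fold higher number from compound 1 to compound 4 (0.31 log units; beyond the scatter)).

As far as these compounds go, a morpholin-4-yl group or a diethylamino group at either place remains open. No available data explain these numbers.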